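The compounds below may be only part of what the source reports. "The series", "measured", "known", "first", "only" and "open" are said of these compounds alone.

Measured in a functional assay on KB cells (Homo sapiens) for inhibition; a lower number here means a stronger inhibitor, a higher number a weaker inhibitor:
- Compound 1 `CNc1c(C#N)c2c(N)ncnc2n1COCCOC`: > 100000 nM, a limit of the assay
- Compound 2 `Cc1cccc(Cn2c(N)c(C#N)c3c(N)ncnc32)c1`: > 100000 nM, a limit of the assay
- Compound 3 `N#Cc1c(N)n(Cc2ccccc2)c2ncnc(N)c12`: 34000 nM

For the measured compounds named here, compound 3 gives 34000 nM, the only actual number among the three. Compound 4 `COCCOCn1c(N)c(C#N)c2c(N)ncnc21` exchanges the phenyl of compound 3: 2-methoxyethoxy in place of phenyl on a saturated chain carbon bound to an aromatic nitrogen. Going by the values given here, the one measured step nearby is an at least 2.9-fold lower number from compound 2 to compound 3 (0.46 log units; beyond the scatter), which alters that same ring. Compound 1 also carries 2-methoxyethoxy, and its > 100000 nM is a limit. A modest rise is therefore expected, an estimated 2.6-fold higher number from compound 3 to compound 4 (0.42 log units; beyond the scatter). For compound 4 the estimate is 90000 nM, with an expected range of 35000 nM to 250000 nM.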

Compound 4, half-maximal inhibitory concentration: 210000 nM
Beside the measured number, compound 4's estimate is 2.3-fold (0.37 log units) below it, within the range that was stated.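

In this assay, the place on a saturated chain carbon bound to an aromatic nitrogen now has its first readable step for a group without a ring: 2-methoxyethoxy in place of phenyl gives a 6.2-fold higher number from compound 3 to compound 4 (0.79 log units; beyond the scatter). Phenyl thus reads as the stronger of the two groups on this core, beyond the scatter. The steps from compound 1 and compound 2 to compound 4 cannot be read, because each starts from a limit: the limit of > 100000 nM in this assay, at which 2 of the 4 values shown sit.

The compounds shown leave open whether the ring or the oxygens of the entering chain account for this step. A cyclohexyl group and a plain pentyl chain on that carbon would separate the two.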